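Replacing Dibutylamino with Pentan-3-yloxy on the Shared Core

The source may report more compounds than this note shows. Statements on the series, on what has been measured and on what is new or still open speak of the compounds shown alone.

Of the compounds shown here, three have been measured in an in vitro assay on 293-EBNA cells for binding affinity to corticotropin-releasing factor receptor 1 (Homo sapiens); a lower number here means a stronger inhibitor, a higher number a weaker inhibitor. Compound 3 `CCCCN(CCCC)c1nc(C)nc2c1ncn2-c1ccc(C(C)C)cc1Br` gives 6.1 nM, the lowest number of the three, although compound 1 `CCC(COC)N(C)c1nc(C)nc2c1nnn2-c1ccc(C(C)C)cc1Br` gives 11.2 nM, a gap that stays within the scatter, so no order between those two can be claimed. Compound 2 `COCCNc1nc(C)nc2c1nnn2-c1c(C)cc(C)cc1C` gives 1200 nM, a gap from compound 3 that lies well beyond the scatter. The step to compound 4 `CCC(CC)Oc1nc(C)nc2c1ncn2-c1ccc(C(C)C)cc1Br` is (pentan-3-yl)oxy in place of dibutylamino on an aromatic carbon. Within the data shown here, no measured pair shows this exact change, so its size cannot be read from the data; a modest weakening is expected, though a step that stays within the scatter would be no surprise. Compound 4 is therefore expected to give 12 nM, with a range from 3 nM to 60 nM. The expected step is a 2.0-fold higher number from compound 3 to compound 4 (0.29 log units; within the scatter).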

Compound 4, inhibition constant: 3.5 nM
Compound 4: the middle estimate sits 3.4-fold (0.54 log units) above what was measured; the measured number falls inside the stated range.
By their numbers in this assay, from the lowest: compounds 4, 3 and 1 (each within the scatter of the next, the first and the last beyond it); then compound 2.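

In this assay, (pentan-3-yl)oxy in place of dibutylamino on the aromatic carbon next to the ring nitrogen gives a 1.7-fold lower number from compound 3 to compound 4 (0.24 log units; within the scatter), so no change can be claimed from this swap. This position thus accepts an oxygen-linked chain with fewer heavy atoms as well as the larger amine. Nothing available explains the size of this step.

From the compounds shown here alone, whether a longer ether such as (heptan-4-yl)oxy, or a smaller amine such as diethylamino, would give a similar number at this position remains open. Also open, going by these compounds, is whether (pentan-3-yl)oxy would behave alike on the core of compound 1.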